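The source may hold more compounds than are shown below. What is called first, only, known or untested is meant among the compounds shown, and "the series" means these compounds.

Compound 1 `O=C(c1ccc(NCc2cncn2Cc2ccc(-c3ccccc3)cc2)cc1-c1ccccc1)N1CCCCC1` was tested in a toxicity assay on NIH3T3 cells (Mus musculus) for cytotoxicity, read by resazurin assay; on this read-out lower numbers stand for an effect already at smaller amounts and higher numbers for an effect only at larger amounts of compound. In this assay compound 1 gives > 1000 nM, which is a limit of the assay and not a measured number. Two further compounds come from the same series. Compound 2 `N#Cc1ccc(NCc2cncn2Cc2ccc(-c3ccccc3)cc2N)cc1-c1ccccc1` in this assay gives > 1000 nM, again a limit rather than a number. Compound 3 `Cc1cccc(-c2cccc(NCc3cncn3Cc3ccccc3)c2)c1` in this assay gives > 1000 nM, once more a limit. All three values therefore sit together at the limit of > 1000 nM in this assay, at which 3 of the 3 values shown sit, so nothing in the measured set separates one compound from another.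

Compound 4 `c1ccc(-c2ccc(Cn3cncc3CNc3ccc(-c4onc5ccccc45)c(-c4ccccc4)c3)cc2)cc1` has not yet been measured in this assay. It differs from compound 1 in one place: a group of 9 heavy atoms (7 carbon, 1 nitrogen, 1 oxygen; one five-membered aromatic ring with 2 hetero atoms, one six-membered aromatic ring of carbon only) in place of a group of 8 heavy atoms (6 carbon, 1 nitrogen, 1 oxygen; one six-membered non-aromatic ring with 1 hetero atom), on an aromatic carbon. Going by the values given here, no measured pair shows what such a change does here, so the expectation rests on compound 1 alone, whose value is a limit. Compound 4 is expected to stay at that limit, with a step that the limit leaves unreadable from compound 1 to compound 4 of none beyond the scatter. The estimate for compound 4 in this assay is 3000 nM, within the range 1000 nM to 10000 nM.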

Compound 4, half-maximal effective concentration: > 10000 nM
Compound 4: a limit, no number; the forecaster's own chance of this, stated with the estimate: 80%; middle value at least 3.3-fold (0.52 log units) away from the limit.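

Going by these compounds alone, compound 1 and compound 4 both give limits of this assay rather than numbers, so no step between them can be read. The compounds shown leave open at what concentration any of them would affect these cells, and what replacing the (piperidin-1-yl)carbonyl group does to that concentration.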